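A bromophenyl variant tested against a set of limits

The compounds below may be only part of what the source reports. "The series", "measured", "known", "first", "only" and "open" are said of these compounds alone.

Compound 1, `Cc1cccc(-n2nncc2CN2C(=O)C3(C(C#N)=C(N)Oc4c3c3nc5ccccc5nc3c3ccccc43)c3ccccc32)c1`, in a functional assay on MCF7 cells (Homo sapiens) for antiproliferative activity, read by MTT assay, with a stated time of 48 h (on this read-out higher numbers stand for weaker inhibition and lower numbers for stronger inhibition), gives > 50000 nM, which is a limit of the assay rather than a number.
Compound 2, `N#CC1=C(N)Oc2c(c3nc4ccccc4nc3c3ccccc23)C12C(=O)N(Cc1cnnn1-c1ccc(Cl)cc1)c1ccccc12`, in this assay gives > 50000 nM, again only a limit.
Compound 3, `N#CC1=C(N)Oc2c(c3nc4ccccc4nc3c3ccccc23)C12C(=O)N(Cc1cnnn1-c1ccccc1Cl)c1ccccc12`, in this assay gives > 50000 nM, also a limit.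

Compound 3 therefore stands at a limit in this assay, and its two companions show nothing else; the limit of > 50000 nM in this assay, at which 3 of the 3 values shown sit, gathers all three values at the same point. Compound 4 is `N#CC1=C(N)Oc2c(c3nc4ccccc4nc3c3ccccc23)C12C(=O)N(Cc1cnnn1-c1ccc(Br)cc1)c1ccccc12`. It differs from compound 3 in one place: 4-bromophenyl in place of 2-chlorophenyl on an aromatic nitrogen. Within the data shown here, three measured steps concern changes at the same aromatic nitrogen: a step that the two limits leave unreadable from compound 1 to compound 2, a step that the two limits leave unreadable from compound 1 to compound 3 and a step that the two limits leave unreadable from compound 2 to compound 3. Among the measured compounds shown here, none of them has a readable size, since every value involved is a limit, so no measured step gives either a direction or a size for the change to compound 4. Swapping one halophenyl for another at this position has no recorded consequence to build on. The expected step of a number no higher from compound 3 to compound 4 (the limit leaves the size open) is accordingly none beyond the scatter, and the result for compound 4 is expected to come back as a limit once more. Compound 4 is estimated at 50000 nM, in a range from 20000 nM to 200000 nM.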

Compound 4, half-maximal inhibitory concentration: 36600 nM
For compound 4 the middle estimate is 1.4-fold (0.14 log units) above the measured one; the measured number falls inside the stated range.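

In this assay compound 4 is the only one of the compounds shown to return a number rather than a limit, so a substituent change on this aromatic nitrogen can now bring a value inside the measurable range, at 36600 nM. Set against its companions, the result reads as an at least 1.3-fold lower number from compound 3 to compound 4 (0.13 log units; that floor lies within the scatter), as an at least 1.3-fold lower number from compound 2 to compound 4 (0.13 log units; that floor lies within the scatter), and as an at least 1.3-fold lower number from compound 1 to compound 4 (0.13 log units; that floor lies within the scatter), so each comparison gives only a floor and none establishes a difference beyond the scatter, not even the exchange of bromo for chloro on the same ring carbon between compound 2 and compound 4. The series as a whole therefore remains gathered almost entirely at one point: the limit of > 50000 nM in this assay, at which 3 of the 4 values shown sit.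

As far as these compounds go, how far compound 1, compound 2 and compound 3 actually lie from compound 4 stays open, since their limits give no size for any of the three steps. Also open, from the compounds shown here alone, is whether a 4-iodophenyl, a 4-methoxyphenyl or a phenyl ring carrying an amine or a carboxylic acid on this nitrogen would give a number in the same region or a clearly lower one.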